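Methoxyphenyl in Place of Chlorophenyl on a Weakly Active Core

This account rests on a few compounds, and the source may have more. Where it says the series, first, only, none or still open, it means among the compounds named here.

Of the compounds shown here, three with a shared core have been measured, each carrying a different aryl group on the amine nitrogen of the six-membered ring. Compound 1 `Cc1ccc(N2CCN(Cn3nc(-c4ccc5c(c4)OCCO5)oc3=S)CC2)c(C)c1` bears a 2,4-dimethylphenyl there, and in a functional assay on BGC-823 cells (Homo sapiens) for antiproliferative activity, read by MTT assay, with a stated time of 48 h (a higher number here means a weaker inhibitor, a lower number a stronger inhibitor), compound 1 gives 28300 nM. Compound 2 `S=c1oc(-c2ccc3c(c2)OCCO3)nn1CN1CCN(c2ccc(Cl)cc2)CC1` carries a 4-chlorophenyl instead; for compound 2 this assay reports only a limit, > 50000 nM. Compound 3 `S=c1oc(-c2ccc3c(c2)OCCO3)nn1CN1CCN(c2cccc(Cl)c2)CC1` carries a 3-chlorophenyl, and for compound 3 the reading is likewise a limit, > 50000 nM. Compound 3 thus stands at the ceiling of the numbers shown (the limit of > 50000 nM in this assay, at which 2 of the 3 values shown sit). Among the measured compounds shown here, the change an at least 1.7-fold higher number from compound 1 to compound 3 (0.24 log units; that floor lies within the scatter) is the only readable comparison to compound 3, and a step that the two limits leave unreadable from compound 2 to compound 3 yields no size at all.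

Compound 4 `COc1ccccc1N1CCN(Cn2nc(-c3ccc4c(c3)OCCO4)oc2=S)CC1` has not yet been measured. It differs from compound 3 by 2-methoxyphenyl in place of 3-chlorophenyl on an amine nitrogen in a ring. For the measured compounds named here, the steps that bear on this change, an at least 1.7-fold higher number from compound 1 to compound 3 (0.24 log units; that floor lies within the scatter) and a step that the two limits leave unreadable from compound 2 to compound 3, offer no movement beyond the scatter, so no clear step in this assay is expected in either direction, and a further limit is quite possible. Compound 4 is expected to give about 45000 nM, within a range from 15000 nM to 150000 nM. The expected step from compound 3 is an at least 1.1-fold lower number from compound 3 to compound 4 (0.04 log units; that floor lies within the scatter), essentially no change beyond the scatter.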

Compound 4, half-maximal inhibitory concentration: 19500 nM
The estimate for compound 4 lay 2.3-fold (0.36 log units) above the measured number; the measured number falls inside the stated range.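

In this assay, the position on the amine nitrogen in a ring now shows a change that can be read: 2-methoxyphenyl gives an at least 2.5-fold lower number from compound 3 to compound 4 (0.40 log units; beyond the scatter) and, set against the other chlorophenyl, an at least 2.5-fold lower number from compound 2 to compound 4 (0.40 log units; beyond the scatter). Set against the 2,4-dimethylphenyl, the same group gives a 1.5-fold lower number from compound 1 to compound 4 (0.16 log units; within the scatter), so these two aryl groups cannot be told apart here, and the aryl groups shown now fall into two sets, one with a measured number and one without. Both chlorophenyl compounds, compound 2 and compound 3, remain limits rather than numbers, and the steps between those two limits cannot be read: the limit of > 50000 nM in this assay, at which 2 of the 4 values shown sit.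

The compounds shown do not separate the identity of the group on the aryl ring from its place, as no chlorophenyl and methoxyphenyl with the same arrangement stand side by side. As far as these compounds go, it also remains open whether a plain phenyl, a hydroxyphenyl or an aminophenyl on this nitrogen would read with compound 1 and compound 4, with the two limits, or apart from both.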